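Removing the aryl ethyl group of compound 3

The source may hold more compounds than are shown below. What is called first, only, known or untested is meant among the compounds shown, and "the series" means these compounds.

Compound 1 `COc1cc(C(C)=O)ccc1OCCCN1CCC(C(c2ccc(F)c(F)c2)c2ccc(F)c(F)c2)CC1`: 2.51 nM
Compound 2 `COc1cc(C(C)=O)ccc1OCCCCN1CCC(C(c2ccc(F)cc2)c2ccc(F)cc2)CC1`: 2.51 nM
Compound 3 `CCc1ccc(OCCCN2CCC(C(c3ccc(F)cc3)c3ccc(F)cc3)CC2)c(OC)c1`: 2.51 nM

Of the compounds shown here, three have been measured in a functional assay (aorta) with Oryctolagus cuniculus as the target; on this read-out lower numbers stand for tighter binding and higher numbers for weaker binding. Compound 1 gives 2.51 nM, compound 2 gives 2.51 nM and compound 3 gives 2.51 nM. On the digits shown, compound 3 stands level with compound 1 and with compound 2; none of the three is set apart from the others beyond the scatter of this assay. No two of these compounds differ in a single place, so no step between measured compounds is available, and what they show is only that three different aryl substitution patterns all land on the same value.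

Compound 4 `COc1ccccc1OCCCN1CCC(C(c2ccc(F)cc2)c2ccc(F)cc2)CC1` is the next compound. Compared with compound 3, the difference is hydrogen in place of ethyl on an aromatic carbon. Since nothing measured speaks directly to this change, the expectation rests on the observation that compound 1, compound 2 and compound 3 all sit at one level despite their differences, which suggests the remaining part of the molecule carries most of the affinity. Compound 4 is therefore expected to lose only a little, a step of a 2.0-fold higher number from compound 3 to compound 4 (0.30 log units; within the scatter) in this assay, which may not exceed the scatter. Compound 4 is estimated at 5 nM, with a range from 1.6 nM to 16 nM.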

Compound 4, dissociation constant: 2.51 nM
The estimate for compound 4 lay 2.0-fold (0.30 log units) above the measured number; low and high end bracket the measured number.
By their numbers in this assay, from the lowest: compounds 1, 2, 3 and 4 (each within the scatter of the next).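

In this assay, among the compounds shown here, putting hydrogen in place of ethyl on the aromatic carbon para to a large group gives no change at the digits printed from compound 3 to compound 4 (within the scatter), and this is the first comparison here in which only one place differs. It shows that, in this pair, the 2-methoxyphenoxy compound stays level with the 4-ethyl-2-methoxyphenoxy compound, so the ethyl group can be lost from this position without a difference that stands out from the scatter of this read-out. Nothing measured here explains this result, and it rests on this single pair.

The compounds shown leave open whether this carbon would keep the same level with a carboxylic acid, an amine or a longer chain in place of the ethyl group, as only ethyl and hydrogen can be compared here. They also leave open whether the same exchange would give the same result with a butyl linker or with the difluorophenyl groups seen in the other compounds, and what happens if the methoxy group is replaced by hydrogen.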